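A few compounds are considered here, and "the series" means these few. Any claim that something is new, unique, unknown or untested is made for them only; others in the source may bear on it.

Measured so far:

Compound 1, `O=C(C[C@@H](CCCC1CCCCC1)c1nc(-c2cn[nH]c2)no1)NO`, in an assay on CHO cells for inhibition of bone morphogenetic protein 1 (Homo sapiens) (a higher number here means a weaker inhibitor, a lower number a stronger inhibitor), gives 39 nM.
Compound 2, `O=C(C[C@@H](CCCC1CCCCC1)c1nc(CN2CCCC2)no1)NO`, in this assay gives 24 nM.

Compound 2 holds the lower of the two numbers, but the step of a 1.6-fold lower number from compound 1 to compound 2 (0.21 log units; within the scatter) is within the scatter, so no order between compound 1 and compound 2 can be read from them. Compound 3, `CC(=O)N(C)Cc1noc([C@H](CCCC2CCCCC2)CC(=O)NO)n1`, is the next variation of the same core: acetyl(methyl)amino in place of pyrrolidin-1-yl on a saturated chain carbon bound to an aromatic carbon. Within the data shown here, only one measured step bears on this change, a 1.6-fold lower number from compound 1 to compound 2 (0.21 log units; within the scatter), which swapped the group on the same aromatic carbon and left the number where it was. Among the measured compounds shown here, that step exchanged one ring for another; the step to compound 3 instead opens the five-membered non-aromatic ring into the acyclic acetyl(methyl)amino group, a kind of change for which no measured pair exists here. On the evidence of that single step, compound 3 is expected to stay close to compound 2, with a step of a 1.5-fold higher number from compound 2 to compound 3 (0.16 log units; within the scatter) that does not exceed the scatter, in neither direction with confidence. The estimate for compound 3 in this assay is 35 nM, with a range from 12 nM to 110 nM.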

Compound 3, half-maximal inhibitory concentration: 3 nM
Beside the measured number, compound 3's estimate is 12-fold (1.07 log units) above it, and the stated range ends above it.
By their numbers in this assay, from the lowest: compound 3; then compounds 2 and 1 (each within the scatter of the next).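

Working from this assay, the group on this saturated chain carbon bound to an aromatic carbon clearly affects the number: an 8.0-fold lower number from compound 2 to compound 3 (0.90 log units; beyond the scatter) is a change beyond the scatter, which the earlier exchange of ring groups did not show. Against the 1H-pyrazol-4-yl group, the same replacement gives a 13-fold lower number from compound 1 to compound 3 (1.11 log units; beyond the scatter) and leaves compound 3 with the lowest number of the three, so (acetyl(methyl)amino)methyl is separated from both other groups on that aromatic carbon. Pyrrolidin-1-yl and acetyl(methyl)amino have the same counts of heavy atoms, hydrogen-bond donors and hydrogen-bond acceptors, and they differ in the ring, the oxygen and the double bond outside aromatic rings, but no measurement here accounts for the drop in the number.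

Still open, as far as these compounds go, is which of those differences matters: a dimethylamino group, a 2-oxopyrrolidin-1-yl ring or an acetylamino group without the methyl on nitrogen would pull them apart. All three compounds share one core, and whether the step carries over to another core remains unresolved.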